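The source may hold more compounds than are shown below. What is called first, only, known or untested is meant among the compounds shown, and "the series" means these compounds.

Measured in a functional assay on HepG2 cells (Homo sapiens) for cytotoxicity, read by MTT assay; on this read-out higher numbers stand for weaker inhibition and lower numbers for stronger inhibition:
- compound 1 `COc1ccc(/C=C/C(=O)c2ccc(OC)c3c2OC(C)(C)C=C3)cc1OCCCN(C)C`: 5550 nM
- compound 2 `CCCCC(=O)Oc1cc(/C=C/C(=O)c2ccc(OC)c3c2OC(C)(C)C=C3)ccc1OC`: 100 nM

Among the compounds with values here, of these two, compound 2 holds the lower number, at 100 nM, so it marks the strong end of what has been seen in this assay so far. The next structure, compound 3 `COc1ccc(/C=C/C(=O)c2ccc(OC)c3c2OC(C)(C)C=C3)cc1CS(C)(=O)=O`, has (methylsulfonyl)methyl in place of (butylcarbonyl)oxy on an aromatic carbon, ortho to a methoxy group ((methylsulfonyl)methyl in place of (butylcarbonyl)oxy on an aromatic carbon). Within the data shown here, only one measured step bears on this change: a 56-fold lower number from compound 1 to compound 2 (1.74 log units; beyond the scatter). That step is large and exchanged 3-(dimethylamino)propyl for the butylcarbonyl that compound 2 now loses, but the oxygen stayed in place there, whereas here it goes as well. Among the measured compounds shown here, the evidence is therefore indirect, and no measured compound carries a sulfonyl group. For the measured compounds named here, with compound 2 at the low end of so short a series, a move toward a higher number seems the likelier outcome, probably smaller than the one measured step. The expected change is a 7.0-fold higher number from compound 2 to compound 3 (0.85 log units; beyond the scatter), a moderate to large step. For compound 3 the estimate is 700 nM, with an expected range from 120 nM to 4000 nM.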

Compound 3, half-maximal inhibitory concentration: 9180 nM
The estimate for compound 3 lay 13-fold (1.12 log units) below the measured number; measured number outside the range, above it.
By their numbers in this assay, from the lowest: compound 2; then compounds 1 and 3 (each within the scatter of the next).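

In this assay, the step of a 92-fold higher number from compound 2 to compound 3 (1.96 log units; beyond the scatter) shows that the low number at this aromatic carbon, ortho to a methoxy group, does not survive replacing (butylcarbonyl)oxy with (methylsulfonyl)methyl, a change that removes the oxygen on the ring as well as the chain. The second step, a 1.7-fold higher number from compound 1 to compound 3 (0.22 log units; within the scatter), shows that 3-(dimethylamino)propoxy and (methylsulfonyl)methyl cannot be told apart in this assay, so among the three groups seen at this position, only (butylcarbonyl)oxy stands apart, although the two groups that read alike have little in common by name. Nothing in the information available accounts for the gap between (butylcarbonyl)oxy and the other two groups.

Going by these compounds, it remains open whether the low number of compound 2 belongs to the whole (butylcarbonyl)oxy group, to its carbonyl, or to its chain, a question that a free hydroxyl, an acetoxy group or a butoxy chain on this carbon could help to separate. On these data alone, it is equally open whether an amide in this place would read like compound 2 or like compound 3.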